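This account rests on a few compounds, and the source may have more. Where it says the series, first, only, none or still open, it means among the compounds named here.

Compounds measured so far: compound 1 `O=C(Nc1ccccc1)c1cccc2oc(=O)[nH]c12` and compound 2 `O=C(Nc1ccccn1)c1cccc2oc(=O)[nH]c12`.

In an assay on isolated protein for binding affinity to metabotropic glutamate receptor 5 (Homo sapiens) (a higher number here means a weaker inhibitor, a lower number a stronger inhibitor), compound 1 gives 2200 nM, and in that same assay compound 2 gives 251 nM. Going by the values given here, compound 2 therefore stands at the lower of the two numbers, the only measured step being an 8.8-fold lower number from compound 1 to compound 2 (0.94 log units; beyond the scatter).

Compound 3 `Cc1nc(NC(=O)c2cccc3oc(=O)[nH]c23)cs1` differs from compound 2 in one place: 2-methyl-1,3-thiazol-4-yl in place of pyridin-2-yl on an amide-type nitrogen. Among the compounds with values here, the one measured step bears on it only loosely, since it swaps a carbocycle for a heteroaromatic ring, while the change to compound 3 replaces one heteroaromatic ring with another of the same size in the same place. Within the data shown here, no measured pair shows what such an exchange does, so nothing beyond the scatter is expected in this assay in either direction. Compound 3 is accordingly estimated at 220 nM, in a range from 70 nM to 700 nM, which means an expected step of a 1.1-fold lower number from compound 2 to compound 3 (0.06 log units; within the scatter).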

Compound 3, inhibition constant: 250 nM
Estimate against measurement, compound 3: 1.1-fold (0.06 log units) below, within the range that was stated.
By their numbers in this assay, from the lowest: compounds 3 and 2 (each within the scatter of the next); then compound 1.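

In this assay, the step (a 1.0-fold lower number from compound 2 to compound 3 (0.00 log units; within the scatter)) shows that, on this amide-type nitrogen, 2-methyl-1,3-thiazol-4-yl and pyridin-2-yl cannot be told apart, even though one is a five-membered aromatic ring with sulfur and the other a six-membered aromatic ring without it. Against phenyl, the thiazole gives a step (an 8.8-fold lower number from compound 1 to compound 3 (0.94 log units; beyond the scatter)) beyond the scatter, so among these three compounds the lower number is no longer tied to pyridin-2-yl alone. Nothing available explains why these two rings read alike.

The compounds shown leave open whether the methyl group on the thiazole contributes anything, since no thiazole without it appears here. They also leave open how a saturated piperidine ring or an open alkyl chain would fare on this nitrogen.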